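Methyl for fluoro on the benzamide ring of compound 3

A few compounds are considered here, and "the series" means these few. Any claim that something is new, unique, unknown or untested is made for them only; others in the source may bear on it.

Measured compounds:
- compound 1 `O=C(NCc1ccc(NC(=O)c2cc(Cl)ccc2N2CCCC2)cc1)OCc1cccnc1`: 750 nM
- compound 2 `Cc1ccc(N2CCCC2)c(C(=O)Nc2ccc(CNC(=O)OCc3cccnc3)cc2)c1`: 1650 nM
- compound 3 `O=C(NCc1ccc(NC(=O)c2cccc(F)c2N2CCCC2)cc1)OCc1cccnc1`: 2020 nM

In a functional assay on HGC-27 cells (Homo sapiens) for inhibition, read by MTT assay, with a stated time of 72 h (on this read-out higher numbers stand for weaker inhibition and lower numbers for stronger inhibition), compound 3 gives 2020 nM, the highest of the three numbers. Its nearest neighbour is compound 2, whose value of 1650 nM lies within the scatter of it, while compound 1 at 750 nM is further away and beyond the scatter. Compound 4 `Cc1cccc(C(=O)Nc2ccc(CNC(=O)OCc3cccnc3)cc2)c1N1CCCC1` has not yet been measured in this assay. It differs from compound 3 in one place: methyl in place of fluoro on an aromatic carbon. Within the data shown here, the one measured step that bears on a methyl entering an aromatic carbon is a 2.2-fold higher number from compound 1 to compound 2 (0.34 log units; beyond the scatter), where methyl replaced chloro rather than fluoro, and at a different place on the ring. That step was modest, and the present change is of a similar kind, so a small rise in the number, or no step beyond the scatter, seems most likely. Compound 4 is therefore expected to give about 2800 nM, with a range from 1200 nM to 6500 nM. The expected step is a 1.4-fold higher number from compound 3 to compound 4 (0.14 log units; within the scatter).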

Compound 4, half-maximal inhibitory concentration: 1030 nM
For compound 4 the middle estimate is 2.7-fold (0.43 log units) above the measured one; the measured number lies below the stated range.
By their numbers in this assay, from the lowest: compounds 1, 4, 2 and 3 (each within the scatter of the next, the first and the last beyond it).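

In this assay, the exchange of fluoro for methyl on the aromatic carbon ortho to a pyrrolidin-1-yl group gives a 2.0-fold lower number from compound 3 to compound 4 (0.29 log units; within the scatter), so at this position the two groups cannot be told apart. Among these compounds, the only earlier step with a methyl entering an aromatic carbon, a 2.2-fold higher number from compound 1 to compound 2 (0.34 log units; beyond the scatter), replaced chloro at a different place on the ring and went beyond the scatter, so the two exchanges do not show one shared outcome for an incoming methyl. No measurement given here explains this difference.

The compounds shown leave open what a methoxy or trifluoromethyl group would give on this same carbon. They also leave open how chloro would read at this position, and how fluoro would read at the place where compound 1 carries chloro.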